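A few compounds are considered here, and "the series" means these few. Any claim that something is new, unique, unknown or untested is made for them only; others in the source may bear on it.

Values so far in an in vivo ADME assay on the whole organism (plasma) for pharmacokinetics, with Rattus norvegicus as the target, at a dose of 50 mg/kg by the oral route (a lower number here means less compound in the circulation, a higher number more compound in the circulation at the dose given), are as follows
- Compound 1 `Cc1cc(C)c(NC(=O)c2sccc2S(=O)(=O)Nc2onc(C)c2Cl)c(C)c1` gives 81600 nM
- Compound 2 `COc1c(C)cc(C)c(NC(=O)c2sccc2S(=O)(=O)Nc2onc(C)c2Cl)c1C` gives 8510 nM
- Compound 3 `Cc1cc(C)c(NS(C)(=O)=O)c(C)c1NC(=O)c1sccc1S(=O)(=O)Nc1onc(C)c1Cl` gives 5250 nM

Compound 3 belongs to the pair at the low end of these numbers, because the gap within that pair (a 1.6-fold lower number from compound 2 to compound 3 (0.21 log units; within the scatter)) is no larger than repeat measurements would produce. It stands far from the top of the series (a 16-fold lower number from compound 1 to compound 3 (1.19 log units; beyond the scatter)).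

The next compound is compound 4 `Cc1cc(C)c(S(N)(=O)=O)c(C)c1NC(=O)c1sccc1S(=O)(=O)Nc1onc(C)c1Cl`, which has sulfamoyl in place of methanesulfonamido on an aromatic carbon. Within the data shown here, the group that enters has never been measured, so no step shows this exact swap, and the case has to be argued from neighbouring steps.

Two steps replace hydrogen on an aromatic carbon, and both are clear drops (a 9.6-fold lower number from compound 1 to compound 2 (0.98 log units; beyond the scatter) and a 16-fold lower number from compound 1 to compound 3 (1.19 log units; beyond the scatter)). Methoxy and methanesulfonamido nevertheless end up within the scatter of each other (a 1.6-fold lower number from compound 2 to compound 3 (0.21 log units; within the scatter)). With only these two groups to compare, this gives a weak hint that a further group in that place may also stay near the low pair. No step beyond the scatter is therefore expected, in either direction, and the expected step is small (a 1.1-fold higher number from compound 3 to compound 4 (0.06 log units; within the scatter)).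

For compound 4 the estimated maximal plasma level is 6000 nM (expected range 2000 nM to 18000 nM).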

Compound 4, maximal plasma concentration: 5590 nM
Beside the measured number, compound 4's estimate is 1.1-fold (0.03 log units) above it; the measured number falls inside the stated range.
By their numbers in this assay, from the lowest: compounds 3, 4 and 2 (each within the scatter of the next); then compound 1.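

With sulfamoyl in this place, on the aromatic carbon para to a methyl group, the result stays level with the methanesulfonamido compound (a 1.1-fold higher number from compound 3 to compound 4 (0.03 log units; within the scatter)), so in this assay exchanging a group joined through nitrogen for one joined through sulfur, with one heavy atom fewer, makes no detectable difference. Sulfamoyl also falls level with methoxy (a 1.5-fold lower number from compound 2 to compound 4 (0.18 log units; within the scatter)) yet stands well apart from hydrogen (a 15-fold lower number from compound 1 to compound 4 (1.16 log units; beyond the scatter)), so three different groups now share one low band, and the large gap among these four compounds is the one that separates hydrogen from all three groups. Nothing available on these compounds explains why the three groups cluster or why the hydrogen compound stands apart.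

Still open, from the compounds shown here alone, is whether the low band holds for any group in this place, or whether a much smaller substituent such as fluorine or a methyl group would bring the number back towards that of compound 1 (81600 nM). Also open, going by these compounds, is how an ionisable group such as an amine or a carboxylic acid would behave here, since every group in the low band so far is neutral.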